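Amide swapped for 3,5-dimethyl-1,2-oxazol-4-yl: an open step

The source may hold more compounds than are shown below. What is called first, only, known or untested is meant among the compounds shown, and "the series" means these compounds.

Compound 1 `Cn1c(-c2ccc(-c3cncnc3)cc2)nnc1C1(c2ccc(Cl)cc2)CCC1` in an assay on isolated protein for inhibition of 11-beta-hydroxysteroid dehydrogenase type 2 (Homo sapiens) (a lower number here means a stronger inhibitor, a higher number a weaker inhibitor), gives only a limit, > 4000 nM.
Compound 2 `Cn1c(-c2ccc(C(=O)NC(C)(C)C)cc2)nnc1C1(c2ccc(Cl)cc2)CCC1` in this assay likewise gives only a limit, > 4000 nM.
Compound 3 `Cn1c(-c2ccc(N)cc2Cl)nnc1C1(c2ccc(Cl)cc2)CCC1` in this assay gives 2300 nM.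

Compound 2 thus sits at the limit of > 4000 nM in this assay, at which 2 of the 3 values shown sit, so its true potency is not pinned to a number. The step from compound 1 to compound 2 reads a step that the two limits leave unreadable from compound 1 to compound 2, and with both ends at limits its size cannot be read. Compound 4 `Cc1noc(C)c1-c1ccc(-c2nnc(C3(c4ccc(Cl)cc4)CCC3)n2C)cc1` differs from compound 2 by 3,5-dimethyl-1,2-oxazol-4-yl in place of (tert-butyl)carbamoyl on an aromatic carbon. Going by the values given here, no measured step bears on this change, and the one actual number, that of compound 3, belongs to a different substitution. The expectation for compound 4 therefore rests on compound 2 alone and stays wide: the estimated step is a step that the limit leaves unreadable from compound 2 to compound 4, no readable change. Compound 4 is expected at 5000 nM, between 1500 nM and 20000 nM, most likely reported again only as a limit.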

Compound 4, half-maximal inhibitory concentration: > 4000 nM
Compound 4 was reported as a limit (the forecaster's own chance of this, stated with the estimate: 65%); the middle value is on the limit's open side.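

Compound 4, like compound 1 and compound 2, gives only a limit, so the steps to compound 4 from the other two cannot be read: the limit of > 4000 nM in this assay, at which 3 of the 4 values shown sit.

From the compounds shown here alone, whether the pyrimidin-5-yl, (tert-butyl)carbamoyl and 3,5-dimethyl-1,2-oxazol-4-yl groups differ in potency stays open.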